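Ester series: nitro to cyclopropylmethoxy step

This account rests on a few compounds, and the source may have more. Where it says the series, first, only, none or still open, it means among the compounds named here.

The series is followed in a functional assay on the whole organism (strain Sprague-Dawley) for inhibition, with Rattus norvegicus as the target, with a stated time of 10 min; on this read-out lower numbers stand for an effect already at smaller amounts and higher numbers for an effect only at larger amounts of compound. Compound 1 `O=C(O)c1cnc(-c2ccccc2[N+](=O)[O-])[nH]c1=O` is the acid with the nitro group; in this assay compound 1 gives > 50 mg/kg, which is a limit of the assay rather than a number. Compound 2 `CCOc1ccc([N+](=O)[O-])cc1-c1ncc(C(=O)O)c(=O)[nH]1` is the second acid; in this assay compound 2 gives 25 mg/kg. Compound 3 `CCOC(=O)c1cnc(-c2ccccc2[N+](=O)[O-])[nH]c1=O` is the ester form of compound 1; for compound 3 this assay reports "not determined" (no result reported), so no number stands for it. The only other entry across the three compounds is the limit of > 50 mg/kg in this assay, at which 1 of the 3 values shown sits. Compound 4 `CCOC(=O)c1cnc(-c2ccccc2OCC2CC2)[nH]c1=O` is the next ester to be measured; it differs from compound 3 by cyclopropylmethoxy in place of nitro on an aromatic carbon. For the measured compounds named here, no step between measured compounds is available, so neither the size nor the direction of this step can be set from the data: the acids show one number and one limit, the esters none. For compound 4 a dose around 30 mg/kg is expected, within 6 mg/kg to 100 mg/kg, with a real chance that only a limit is returned.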

Compound 4, dose for 50% inhibition: 0.3 mg/kg
For compound 4 the middle estimate is 100-fold (2.00 log units) above the measured one; the measured number lies below the stated range.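

No step can be read from compound 3 to compound 4: in this assay compound 3 gives "not determined" (no result reported), so compound 4, with 0.3 mg/kg, stands without a partner. The compounds shown leave open how much of that value belongs to the cyclopropylmethoxy group and how much to the ester form, and the acid with the nitro group offers only a limit: the limit of > 50 mg/kg in this assay, at which 1 of the 4 values shown sits.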